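Adding a ring methoxy to compound 1

A few compounds are considered here, and "the series" means these few. Any claim that something is new, unique, unknown or untested is made for them only; others in the source may bear on it.

Values so far in a functional assay on the whole organism (strain Sprague-Dawley) for inhibition, with Rattus norvegicus as the target, with a stated time of 10 min; on this read-out higher numbers stand for an effect only at larger amounts of compound and lower numbers for an effect already at smaller amounts
- compound 1 `CCOc1ccccc1-c1ncc(C(=O)O)c(=O)[nH]1` gives 0.5 mg/kg
- compound 2 `CCCCCOc1ccccc1-c1ncc(C(=O)O)c(=O)[nH]1` gives 3 mg/kg
- compound 3 `O=C(O)c1cnc(-c2ccccc2OCc2ccccc2)[nH]c1=O` gives 5 mg/kg

Compound 1 has the lowest of the three numbers. Both measured steps away from it lie beyond the scatter, and a 6.0-fold higher number from compound 1 to compound 2 (0.78 log units; beyond the scatter) and a 10-fold higher number from compound 1 to compound 3 (1.00 log units; beyond the scatter) are modest in size. The remaining step, a 1.7-fold higher number from compound 2 to compound 3 (0.22 log units; within the scatter), lies within the scatter, so compounds 2 and 3 are not separated.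

The next compound is compound 4 `CCOc1ccc(OC)cc1-c1ncc(C(=O)O)c(=O)[nH]1` and it carries methoxy in place of hydrogen on an aromatic carbon, para to an ethoxy group and meta to a large group. The counted difference from compound 1 is methoxy in place of hydrogen on an aromatic carbon and nothing else changes.

Among the measured compounds shown here, no measured step touches the aromatic ring. All three alter the saturated chain on the oxygen, so they bear on this change only indirectly. The data hold no direct evidence on direction. Still, compound 1 sits at the low end with 0.5 mg/kg and both changes made to it raised the number, so a small upward step is expected in this assay rather than a further fall. The expected size is a 2.0-fold higher number from compound 1 to compound 4 (0.30 log units; within the scatter) and this lies below the two modest steps. For compound 4 the estimated value is 1 mg/kg with an expected range from 0.3 mg/kg to 4 mg/kg as the working bracket.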

Compound 4, dose for 50% inhibition: 0.2 mg/kg
For compound 4 the middle estimate is 5.0-fold (0.70 log units) above the measured one; the measured number lies below the stated range.
By their numbers in this assay, from the lowest: compound 4; then compound 1; then compounds 2 and 3 (each within the scatter of the next).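

In this assay, methoxy in place of hydrogen on the aromatic carbon para to an ethoxy group and meta to a large group gives a 2.5-fold lower number from compound 1 to compound 4 (0.40 log units; beyond the scatter). Among the compounds shown here, this is the first measured change on the aromatic ring rather than on the saturated chain on the oxygen, and the first step towards a lower number, since both steps away from compound 1 on that chain went upward, so the ring position is open to substitution without loss of effect and the step, though modest, makes compound 4 the lowest of the four. No measurement accompanies this result that would tie the step to any property of the methoxy group, so it stands as an observation only.

A single group at a single ring position is shown, so it remains open whether a hydroxyl, a chlorine or an amine at this carbon would move the number the same way, and whether the other aromatic carbons of that ring respond alike. Going by these compounds, it is also open whether the same methoxy on compound 2 or compound 3 would lower the number as it does on compound 1.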